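The source may hold more compounds than are shown below. What is called first, only, known or untested is meant among the compounds shown, and "the series" means these compounds.

Three measured compounds share one core and differ only in the group carried on a saturated ring carbon. In a functional assay on the whole organism for inhibition, with Rattus norvegicus as the target, read by paw edema, with stated times of 30 min and 4 h, at a dose of 10 mg/kg by the oral route (on this read-out lower numbers stand for less inhibition and higher numbers for more inhibition at the one dose given (going by the name of the read-out)), compound 1 `COc1ccc(C2CC(C3C(=O)c4ccccc4C3=O)=NC(=O)N2)cc1` gives 10%, compound 2 `O=C1N=C(C2C(=O)c3ccccc3C2=O)CC(/C=C/c2ccccc2)N1` gives 16%, and compound 3 `O=C1N=C(C2C(=O)c3ccccc3C2=O)CC(c2ccccc2O)N1` gives 16%. Compound 3 therefore stands level with compound 2 at the digits shown, the pair being the highest of the three numbers, while every step among them stays within the scatter: a number 6 percentage points higher from compound 1 to compound 2 (within the scatter), a number 6 percentage points higher from compound 1 to compound 3 (within the scatter) and no change at the digits printed from compound 2 to compound 3 (within the scatter). Compound 4 `O=C1N=C(C2C(=O)c3ccccc3C2=O)CC(c2ccco2)N1` makes a further swap at the same position: furan-2-yl in place of 2-hydroxyphenyl on a saturated ring carbon. Because each earlier swap at this carbon gave a number 6 percentage points higher from compound 1 to compound 2 (within the scatter), a number 6 percentage points higher from compound 1 to compound 3 (within the scatter) or no change at the digits printed from compound 2 to compound 3 (within the scatter), no step beyond the scatter is expected here either, the estimated change being a number 2 percentage points lower from compound 3 to compound 4 (within the scatter). Compound 4 is thus expected to give about 14%, with a likely range from 4% to 26%.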

Compound 4, a percentage reported as inhibition, in the whole organism at one dose (the size of the read-out at that dose, not a potency): 7%
For compound 4 the middle estimate is 7 percentage points above the measured one; the range from low to high includes it.
By their numbers in this assay, from the lowest: compounds 4, 1, 2 and 3 (each within the scatter of the next).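

In this assay, furan-2-yl on this saturated ring carbon gives a number 9 percentage points lower from compound 3 to compound 4 (within the scatter) and a number 9 percentage points lower from compound 2 to compound 4 (within the scatter) and a number 3 percentage points lower from compound 1 to compound 4 (within the scatter). So even a five-membered aromatic ring with 1 hetero atom, which also removes the hydrogen-bond donor of 2-hydroxyphenyl, brings no step beyond the scatter at this position. No measurement is available that would explain these small differences. As far as these compounds go, whether an amine, a carboxylic acid or a longer chain on this carbon would move the number beyond the scatter stays open.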